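Methyl removal on the aryl ring of the bicyclic lactam series

This account rests on a few compounds, and the source may have more. Where it says the series, first, only, none or still open, it means among the compounds named here.

Measured so far:
compound 1 `O=C(CCC(=O)c1cccs1)NCCCO`, 300 mg/kg
compound 2 `Cc1ccc(C23CCC(=O)N2CCCO3)c(C)c1`, 150 mg/kg
compound 3 `O=C(CCC(=O)c1ccc(Cl)c(Cl)c1)NCCCO`, 500 mg/kg

In a functional assay on the whole organism (Central nervous system) with Mus musculus as the target (on this read-out higher numbers stand for an effect only at larger amounts of compound and lower numbers for an effect already at smaller amounts), compound 2 holds the lowest of the three numbers. Compound 1 gives 300 mg/kg, a gap from compound 2 that stays within the usual scatter, so the two cannot be ranked against each other. Compound 3 gives 500 mg/kg, and here the gap from compound 2 lies beyond the scatter. Going by the values given here, compounds 1 and 3 share an open-chain amide with a hydroxypropyl arm, while compound 2 carries the fused bicyclic core; no pair of measured compounds differs in only one place, so no single step can be read from them.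

Compound 4 `Cc1ccc(C23CCC(=O)N2CCCO3)cc1` differs from compound 2 by hydrogen in place of methyl on an aromatic carbon. Nothing measured in this assay speaks to the loss of an aryl methyl. The expectation for compound 4 is therefore a small step of a 1.2-fold higher number from compound 2 to compound 4 (0.08 log units; within the scatter), not beyond the scatter, with neither direction favoured. The estimate for compound 4 in this assay is 180 mg/kg, with a range from 80 mg/kg to 400 mg/kg.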

Compound 4, dose for half-maximal effect: 160 mg/kg
Compound 4: middle estimate off by 1.1-fold (0.05 log units), on the high side, within the range that was stated.
By their numbers in this assay, from the lowest: compounds 2, 4, 1 and 3 (each within the scatter of the next, the first and the last beyond it).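

In this assay, hydrogen in place of methyl on an aromatic carbon, ortho to a large group and meta to a methyl group, gives a 1.1-fold higher number from compound 2 to compound 4 (0.03 log units; within the scatter), so the two compounds cannot be told apart. Going by these compounds alone, the earlier compounds offered no step in a single place, and this one is the first reading for the series: at this position, the read-out does not separate methyl from hydrogen. No accompanying measurement bears on this result, so the step stands without any explanation.

The compounds shown leave open whether an amine or a methoxy group at this position would give a number beyond the scatter from compound 2. They also leave open whether the same exchange of methyl for hydrogen at the methyl group remaining in compound 4 would stay within the scatter.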